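A few compounds are considered here, and "the series" means these few. Any claim that something is new, unique, unknown or untested is made for them only; others in the source may bear on it.

Compound 2 `CN(C(=O)NC(=O)c1ccc(Cl)cc1Cl)c1nc(C(F)(F)F)c(C(=O)N/N=C/c2ccc(C(F)(F)F)cc2)s1` is measured in a functional assay on HepG2 cells (Homo sapiens) for inhibition, read by MTT assay, with a stated time of 72 h (a lower number here means a stronger inhibitor, a higher number a weaker inhibitor), where compound 2 gives 12.4 ug/mL. Among the two numbers at hand this is the one standing highest, though its nearest companion, compound 1 `CN(C(=O)NC(=O)c1ccc(Cl)cc1Cl)c1nc(C(F)(F)F)c(C(=O)N/N=C/c2cccc(C(F)(F)F)c2)s1`, which in this assay gives 11.2 ug/mL, differs by a step of a 1.1-fold higher number from compound 1 to compound 2 (0.04 log units; within the scatter) that is within the scatter, so no order between the two is claimed. Compound 3 `CNc1nc(C)c(C(=O)N/N=C/c2cccc(C(F)(F)F)c2)s1` is a separate case: in this assay compound 3 gives only a limit, > 100 ug/mL. That one of the three values sits at this limit is recorded as the limit of > 100 ug/mL in this assay, at which 1 of the 3 values shown sits.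

The next compound, compound 4 `CN(C(=O)NC(=O)c1ccc(C(F)(F)F)cc1)c1nc(C(F)(F)F)c(C(=O)N/N=C/c2ccc(C(F)(F)F)cc2)s1`, differs from compound 2 in a single place: 4-(trifluoromethyl)phenyl in place of 2,4-dichlorophenyl on a carbonyl carbon. Going by the values given here, the only measured step in this set, a 1.1-fold higher number from compound 1 to compound 2 (0.04 log units; within the scatter), concerns the aryl carried on the carbon with a double bond to nitrogen, not the group on the carbonyl carbon, and it was within the scatter. Among the compounds with values here, no measured step touches the part of the molecule that changes here, so the size and direction of the coming step cannot be taken from the data; the expectation is therefore for a step not clearly beyond the scatter. Compound 4 is thus estimated to give 14 ug/mL in this assay, within a range from 5 ug/mL to 40 ug/mL. The step this estimate implies, a 1.1-fold higher number from compound 2 to compound 4 (0.05 log units; within the scatter), is expected to be small.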

Compound 4, half-maximal inhibitory concentration: > 100 ug/mL
Compound 4 ended at the assay's limit (the forecaster's own chance of this, stated with the estimate: 15%); middle value at least 7.1-fold (0.85 log units) away from the limit.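

Going by these compounds alone, until now, the only readable step in this set concerned the aryl on the carbon with a double bond to nitrogen, and that step stayed within the scatter, so nothing was known about how much the group on the carbonyl carbon counts. In this assay, exchanging 2,4-dichlorophenyl for 4-(trifluoromethyl)phenyl on that carbonyl carbon gives an at least 8.0-fold higher number from compound 2 to compound 4 (0.90 log units; beyond the scatter), which shows that this position, unlike the one varied before, does not tolerate every aryl group with the rest of compound 2 held fixed. The value of compound 4 is a limit of the assay and not a number, so the true size of the step stays unknown, and it is the second such value in the set: the limit of > 100 ug/mL in this assay, at which 2 of the 4 values shown sit.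

The compounds shown cannot separate the departure of the two chlorine atoms from the arrival of the trifluoromethyl group, and a plain phenyl or a phenyl carrying a single chlorine on this carbonyl carbon would be needed to tell these apart. Going by these compounds, it also stays open whether the same exchange has a comparable effect when 3-(trifluoromethyl)phenyl sits on the carbon with a double bond to nitrogen.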